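The source may report more compounds than this note shows. Statements on the series, on what has been measured and on what is new or still open speak of the compounds shown alone.

In a functional assay on cells (Homo sapiens) for antiproliferative activity, read by MTT assay, with a stated time of 48 h (a lower number here means a stronger inhibitor, a higher number a weaker inhibitor), three compounds sharing one core have been measured. Compound 1 `N#Cc1nc2c(-c3nc4ccccc4[nH]3)c(N)n(CCN3CCCC3)c2nc1C#N` is reported only as a limit, > 50000 nM. Compound 2 `N#Cc1nc2c(-c3nc4ccccc4[nH]3)c(N)n(CCO)c2nc1C#N`, the starting point here, is also reported only as a limit, > 50000 nM. Compound 3 `CCCCn1c(N)c(-c2nc3ccccc3[nH]2)c2nc(C#N)c(C#N)nc21` is likewise reported only as a limit, > 50000 nM. Every reading so far is therefore the same: the limit of > 50000 nM in this assay, at which 3 of the 3 values shown sit.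

Compound 4 `CCN(CC)CCCCn1c(N)c(-c2nc3ccccc3[nH]2)c2nc(C#N)c(C#N)nc21` keeps the core and alters the chain: 2-(diethylamino)ethyl in place of hydroxy on a saturated chain carbon, two bonds along the chain from an aromatic nitrogen. Cut further out, the same difference reads 2-hydroxyethyl to 4-(diethylamino)butyl.

For the measured compounds named here, three measured steps bear on this place: a step that the two limits leave unreadable from compound 1 to compound 2, a step that the two limits leave unreadable from compound 1 to compound 3 and a step that the two limits leave unreadable from compound 2 to compound 3. None has a readable size, so they offer no direction, and no clear gain or loss can be forecast. In this assay, the step expected is a number no higher from compound 2 to compound 4 (the limit leaves the size open). Compound 4 is estimated at 50000 nM, with an expected range of 15000 nM to 100000 nM.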

Compound 4, half-maximal inhibitory concentration: 640 nM
For compound 4 the middle estimate is 78-fold (1.89 log units) above the measured one, outside the stated range (below it).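

In this assay, for the compounds shown here, the earlier compounds could show no effect of this chain, as the steps among them cannot be read, but the change to the 2-(diethylamino)ethyl group now gives an at least 78-fold lower number from compound 2 to compound 4 (1.89 log units; beyond the scatter), and diethylamino in place of hydrogen at the chain end gives an at least 78-fold lower number from compound 3 to compound 4 (1.89 log units; beyond the scatter). An amine on the chain is not enough by itself, as compound 1 also carries one, and 2-(diethylamino)ethyl in place of pyrrolidin-1-yl gives an at least 78-fold lower number from compound 1 to compound 4 (1.89 log units; beyond the scatter). Compound 4 is the only one of the set that gives a number rather than a limit: the limit of > 50000 nM in this assay, at which 3 of the 4 values shown sit.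

The compounds shown leave open whether the chain length or the amine itself matters more, as the two differ together between compound 1 and compound 4. A 3-(diethylamino)propyl chain, a 4-(pyrrolidin-1-yl)butyl chain or a longer chain ending in diethylamino could separate the two.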